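The source may report more compounds than this note shows. Statements on the series, on what has been measured and on what is new or still open speak of the compounds shown alone.

Compound 1 `CC(C)c1ccc(-c2nc(SCc3cn(CC(=O)NC(=O)Nc4ccccn4)nn3)nc(Nc3ccccc3F)c2C#N)cc1` and compound 2 `Cc1ccccc1Nc1nc(SCc2cn(CC(=O)NC(=O)Nc3ccccn3)nn2)nc(-c2ccc(C(C)C)cc2)c1C#N` are the two measured compounds; in a functional assay on B16-F10 cells (Mus musculus) for inhibition, read by MTT assay, with a stated time of 72 h (a lower number here means a stronger inhibitor, a higher number a weaker inhibitor), compound 1 gives 8380 nM, and compound 2 gives 18600 nM.

Going by the values given here, compound 2 therefore stands highest of the two numbers in this assay, and the single measured step is a 2.2-fold higher number from compound 1 to compound 2 (0.35 log units; beyond the scatter). Compound 3 `CC(C)c1ccc(Nc2nc(SCc3cn(CC(=O)NC(=O)Nc4ccccn4)nn3)nc(-c3ccc(C(C)C)cc3)c2C#N)cc1` differs from compound 2 by 4-isopropylphenyl in place of 2-methylphenyl on a nitrogen on an aromatic ring. Among the compounds with values here, the only step that bears on this change is a 2.2-fold higher number from compound 1 to compound 2 (0.35 log units; beyond the scatter), a modest move to a higher number on swapping one small substituent for another on the same aniline ring; it does not test a change of this size, and nothing else in the data does. Compound 3 is consequently expected to give a step of a 1.2-fold lower number from compound 2 to compound 3 (0.09 log units; within the scatter), close to or just beyond the scatter, with no firm direction. The estimate for compound 3 is 15000 nM, with a range from 5000 nM to 45000 nM.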

Compound 3, half-maximal inhibitory concentration: 4380 nM
Compound 3: middle estimate off by 3.4-fold (0.53 log units), on the high side; the whole stated range lies above it.
By their numbers in this assay, from the lowest: compounds 3 and 1 (each within the scatter of the next); then compound 2.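

In this assay, the nitrogen position accepts 4-isopropylphenyl without loss, and this replacement of 2-methylphenyl gives a 4.2-fold lower number from compound 2 to compound 3 (0.63 log units; beyond the scatter), a step beyond the scatter. Against the 2-fluorophenyl group, the same entering group gives a 1.9-fold lower number from compound 1 to compound 3 (0.28 log units; within the scatter), which lies within the scatter, so compound 1 and compound 3 cannot be ordered. The position is therefore not limited to the two small 2-substituted phenyl groups seen first, and no measurement shown here gives a reason for these steps.

The compounds shown leave open whether the step from compound 2 follows from the isopropyl group itself or from the loss of the 2-methyl group. A 4-methylphenyl group or an unsubstituted phenyl group on the same nitrogen would separate these two readings.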